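Moving a Methoxy Group on Two Related Acid Scaffolds

The source may report more compounds than this note shows. Statements on the series, on what has been measured and on what is new or still open speak of the compounds shown alone.

Compound 1 `COC(=O)c1cccc(OCc2oc(-c3ccccc3OC)nc2C)c1` and compound 2 `COC(=O)c1cccc(OCc2oc(-c3cccc(OC)c3)nc2C)c1` are built on one core, while compound 3 `COc1ccccc1-c1nc(C)c(COc2ccccc2C(=O)O)o1` is built on another; the difference between the two cores is not broken down here. In a physicochemical assay for solubility, tested at 500 uM (on this read-out lower numbers stand for lower solubility and higher numbers for higher solubility), compound 1 gives 44100 nM, compound 2 gives 24100 nM, and compound 3 gives 402000 nM, the highest of the three numbers, standing a clear distance above both compound 1 and compound 2.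

Among the measured compounds shown here, the one change within the first pair is 3-methoxyphenyl in place of 2-methoxyphenyl on an aromatic carbon, and it made a 1.8-fold lower number from compound 1 to compound 2 (0.26 log units; within the scatter). Compound 4 `COc1cccc(-c2nc(C)c(COc3ccccc3C(=O)O)o2)c1` has not yet been measured in this assay. It differs from compound 3 by 3-methoxyphenyl in place of 2-methoxyphenyl on an aromatic carbon, which is the same change, at the same place on the ring, as the one that turns compound 1 into compound 2; the change occurs twice among these compounds.

Because a 1.8-fold lower number from compound 1 to compound 2 (0.26 log units; within the scatter) stayed within the scatter, compound 4 is expected to stay close to compound 3, with a step of about a 1.6-fold lower number from compound 3 to compound 4 (0.21 log units; within the scatter). This rests on a single earlier instance of the change, so the range is kept wide. Compound 4 is expected to give roughly 250000 nM in this assay, most likely somewhere between 100000 nM and 500000 nM.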

Compound 4, solubility: 264000 nM
For compound 4 the middle estimate is 1.1-fold (0.02 log units) below the measured one; the range from low to high includes it.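

In this assay, the change to 3-methoxyphenyl in place of 2-methoxyphenyl gave a 1.5-fold lower number from compound 3 to compound 4 (0.18 log units; within the scatter), while on the core of compound 1 the same change gave a 1.8-fold lower number from compound 1 to compound 2 (0.26 log units; within the scatter), so the step stayed within the usual scatter on both cores. This shows only that, across these two pairs, the change carried from one core to the other without a step that can be told from the scatter; with just two instances, it does not show that the same would hold on any further core, and steps of this size do not establish a real difference or a shared direction. Nothing available here bears on why the two steps came out as they did.

The compounds shown leave open whether the same result would hold with a group other than methoxy on the phenyl ring, such as a trifluoromethyl, a nitrile or an amine. They also leave open what would happen if the methyl group on the five-membered aromatic ring gave way to a longer chain.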